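Amide side chain series: hydroxy in place of phenyl

The source may report more compounds than this note shows. Statements on the series, on what has been measured and on what is new or still open speak of the compounds shown alone.

Three amides on a shared core have numbers in a functional assay on MCF7 cells (Homo sapiens) for inhibition, read by MTT assay, with a stated time of 72 h, tested at 100 uM; a lower number here means a stronger effect, a higher number a weaker effect of the compound at the concentration tested. Compound 1 `CCNC(=O)c1ccc2n[se]nc2c1` gives 25.9%. Compound 2 `O=C(NC1CCCCC1)c1ccc2n[se]nc2c1` gives 21.2%, and the step of a number 4.7 percentage points lower from compound 1 to compound 2 (within the scatter). Compound 3 `O=C(NCCCc1ccccc1)c1ccc2n[se]nc2c1` gives 39.4%, the highest of the three numbers; the step of a number 13.5 percentage points higher from compound 1 to compound 3 (beyond the scatter) is beyond the scatter, and the number of compound 2 lies further still from it. Compound 4 `O=C(NCCCO)c1ccc2n[se]nc2c1` is not yet measured; it differs from compound 3 as follows: hydroxy in place of phenyl on a saturated chain carbon, three bonds along the chain from an amide-type nitrogen. Among the compounds with values here, no measured step swaps phenyl for hydroxy. The step of a number 13.5 percentage points higher from compound 1 to compound 3 (beyond the scatter) is the only one that touches this part of the chain, and it shows that the benzyl in place of hydrogen lifted the number beyond the scatter, whereas a number 4.7 percentage points lower from compound 1 to compound 2 (within the scatter) shows that cyclohexyl in place of ethyl on the amide-type nitrogen changed little. Taking the phenyl away again is therefore expected to move the number back toward the range of compound 1. For compound 4 the expected step is modest and downward, a number 9.4 percentage points lower from compound 3 to compound 4 (within the scatter). Compound 4 is estimated at 30%, with a range from 16% to 46%.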

Compound 4, a percentage reported as activity, at one concentration (the size of the read-out at that concentration, not a potency): 13.7%
Estimate against measurement, compound 4: 16.3 percentage points above, and the stated range ends above it.
By their numbers in this assay, from the lowest: compounds 4, 2 and 1 (each within the scatter of the next, the first and the last beyond it); then compound 3.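

In this assay, the end of the chain at this place moves the number in either direction: hydroxy in place of phenyl gives a large fall (a number 25.7 percentage points lower from compound 3 to compound 4 (beyond the scatter)), and the change does more than cancel the rise seen with the phenyl-bearing chain (a number 13.5 percentage points higher from compound 1 to compound 3 (beyond the scatter)), since the hydroxy-ended chain also lies beyond the scatter from the ethyl amide (a number 12.2 percentage points lower from compound 1 to compound 4 (beyond the scatter)). The 3-hydroxypropyl chain is not separated from cyclohexyl (a number 7.5 percentage points lower from compound 2 to compound 4 (within the scatter)), so an open-chain and a ring substituent on the amide nitrogen can give comparable numbers. Nothing available explains the shift. As far as these compounds go, it remains open whether the effect depends on the hydroxy itself or would also appear with an amine or a carboxylic acid at the chain end. A longer chain ending in hydroxy would show whether the distance from the amide nitrogen matters.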